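From an aminoethylamino chain to a sulfonyloxy group

This account rests on a few compounds, and the source may have more. Where it says the series, first, only, none or still open, it means among the compounds named here.

In a functional assay on MDA-MB-435 cells (Homo sapiens) for cytotoxicity, read by MTT assay, with a stated time of 72 h (a higher number here means a weaker inhibitor, a lower number a stronger inhibitor), compound 1 (`NCCCNc1c(C(=O)NCc2ccc(F)cc2)nc(Br)c2cccnc12`) gives 5000 nM, compound 2 (`CN(C)CCCNc1c(C(=O)NCc2ccc(F)cc2)nc(Br)c2cccnc12`) gives 7000 nM and compound 3 (`NCCNc1c(C(=O)NCc2ccc(F)cc2)nc(Br)c2cccnc12`) gives 12000 nM. Two steps fix where compound 3 stands: a 1.7-fold higher number from compound 2 to compound 3 (0.23 log units; within the scatter) and a 2.4-fold higher number from compound 1 to compound 3 (0.38 log units; beyond the scatter). Compound 4 (`Cc1ccc(S(=O)(=O)Oc2c(C(=O)NCc3ccc(F)cc3)nc(Br)c3cccnc23)cc1`) has ((4-methylphenyl)sulfonyl)oxy in place of (2-aminoethyl)amino on an aromatic carbon. The measured steps, with a 1.4-fold higher number from compound 1 to compound 2 (0.15 log units; within the scatter) as the third, only alter the amine chain and are modest at most, so none of them measures the loss of that chain. In this assay, going by these compounds, no step beyond the scatter is therefore expected, and the direction remains open. The expected step is a 1.3-fold lower number from compound 3 to compound 4 (0.12 log units; within the scatter). For compound 4 the estimated value is 9000 nM, with an expected range from 2500 nM to 30000 nM.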

Compound 4, half-maximal inhibitory concentration: > 20000 nM
Compound 4 was reported as a limit; the forecaster's own chance of this, stated with the estimate: 25%; middle value at least 2.2-fold (0.34 log units) away from the limit.
By their numbers in this assay, from the lowest: compounds 1, 2 and 3 (each within the scatter of the next, the first and the last beyond it). At a limit, above all of these: compound 4.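

In this assay compound 4 gives > 20000 nM, which is a limit of the assay and not a number. Exchanging the whole amine chain on this aromatic carbon for ((4-methylphenyl)sulfonyl)oxy gives an at least 1.6-fold higher number from compound 3 to compound 4 (0.22 log units; that floor lies within the scatter), while the longer chains give an at least 2.8-fold higher number from compound 2 to compound 4 (0.45 log units; beyond the scatter) and an at least 4.0-fold higher number from compound 1 to compound 4 (0.60 log units; beyond the scatter). So this position, previously varied only within the chain, now shows that an aromatic sulfonate without any amine brings no gain in this assay, and against the two propyl chains it costs activity beyond the scatter.

Going by these compounds, how far compound 4 lies past its limit stays unknown. On these data alone, whether losing the amine or adding the 4-methylphenyl ring matters more stays open, and a hydroxyl or methoxy group on this carbon would separate the two.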